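Solubility of a chloro analogue: one step to go on

The source may hold more compounds than are shown below. What is called first, only, known or untested is meant among the compounds shown, and "the series" means these compounds.

Measured so far in a physicochemical assay for solubility, at pH 7.4; a lower number here means a less soluble compound, a higher number a more soluble compound:
- compound 1 `C[C@H]1[C@H](N)CN1c1cc2c(cc1F)c(=O)c(C(=O)O)cn2C1CC1`: 9.9 ug/mL
- compound 2 `C[C@H]1[C@H](N)CN1c1c(F)cc2c(=O)c(C(=O)O)cn(C3CC3)c2c1F`: 23.2 ug/mL

Of these two, compound 2 stands highest, at 23.2 ug/mL. Going by the values given here, the only measured step is a 2.3-fold higher number from compound 1 to compound 2 (0.37 log units; beyond the scatter), and in it a fluoro replaces an aromatic hydrogen. The unmeasured compound 3 `C[C@H]1[C@H](N)CN1c1c(F)cc2c(=O)c(C(=O)O)cn(C3CC3)c2c1Cl` keeps the shared core and alters that same carbon again: chloro in place of fluoro on an aromatic carbon. In words, this is chloro in place of fluoro on an aromatic carbon.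

Among the compounds with values here, only that one step bears on the new change. It is modest, though beyond the scatter. It swapped hydrogen for fluoro, so it hints at how far one atom at this carbon can move the number but not which way chloro will move it. Within the data shown here, no measured compound carries chloro. A step no larger than the measured one is therefore expected in this assay, leaning tentatively downward, and a result within the scatter would be no surprise. The estimated change is a 1.5-fold lower number from compound 2 to compound 3 (0.19 log units; within the scatter). For compound 3 the expected value is 15 ug/mL, with an estimated range of 7 ug/mL to 32 ug/mL.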

Compound 3, solubility: 12 ug/mL
Estimate against measurement, compound 3: 1.3-fold (0.10 log units) above, within the range that was stated.
By their numbers in this assay, from the lowest: compounds 1, 3 and 2 (each within the scatter of the next, the first and the last beyond it).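

At this carbon, which is ortho to a fused ring and ortho to a group of 6 heavy atoms, the direct comparison of the two halogens in this assay gives a 1.9-fold lower number from compound 2 to compound 3 (0.29 log units; within the scatter), so fluoro and chloro cannot be told apart here. Measured against hydrogen at the same carbon, chloro gives a 1.2-fold higher number from compound 1 to compound 3 (0.08 log units; within the scatter), while fluoro gave a 2.3-fold higher number from compound 1 to compound 2 (0.37 log units; beyond the scatter), so only the fluoro step clears the scatter. Compound 3 therefore lies within the scatter of both compound 1 and compound 2, even though those two stand apart, and these numbers cannot place chloro closer to hydrogen or to fluoro.

No measurement shown here gives a reason for any of these numbers. Still open, from the compounds shown here alone, is whether a group of another kind on this carbon, such as methyl, methoxy or nitrile, would move the number beyond the scatter, and whether repeat measurements would separate compound 3 from either of the other two.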